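Pairing a nitrile phenyl with a tighter core

The source may hold more compounds than are shown below. What is called first, only, known or untested is meant among the compounds shown, and "the series" means these compounds.

Measured compounds in an in vitro functional assay on HEK293 cells for antagonist activity at melanin-concentrating hormone receptor 1 (Homo sapiens), read by GTPgammaS binding, with a stated time of 45 min; a higher number here means a weaker inhibitor, a lower number a stronger inhibitor:
Compound 1, `Cc1ccc(CN2CCC(NC(=O)N(CC(=O)C(C)(C)O)Cc3ccc(-c4ccc(F)cc4)cc3)CC2)cc1`, gives 4530 nM.
Compound 2, `Cc1ccc(CN2CCC(NC(=O)N(CC(=O)C(C)(C)O)Cc3ccc(-c4cccc(C#N)c4)cc3)CC2)cc1`, gives 5000 nM.
Compound 3, `Cc1ccc(CN2CCC(CCN(Cc3ccc(-c4ccc(F)cc4)cc3)C(=O)NC(C)(C)CO)CC2)cc1`, gives 41.4 nM.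

Compound 1 and compound 2 share one core and differ by 3-cyanophenyl in place of 4-fluorophenyl on an aromatic carbon; the step of a 1.1-fold higher number from compound 1 to compound 2 (0.04 log units; within the scatter) lies within the scatter. Compound 3 carries a different core, and the difference between the two cores is not broken down here; its values against compound 1 and compound 2 show a much lower number in this assay. Compound 4, `Cc1ccc(CN2CCC(CCN(Cc3ccc(-c4cccc(C#N)c4)cc3)C(=O)NC(C)(C)CO)CC2)cc1`, is not yet measured and differs from compound 3 by 3-cyanophenyl in place of 4-fluorophenyl on an aromatic carbon, the same change as from compound 1 to compound 2. Because that earlier step was a 1.1-fold higher number from compound 1 to compound 2 (0.04 log units; within the scatter), the step from compound 3 to compound 4 is expected to be similarly small, a 1.1-fold higher number from compound 3 to compound 4 (0.04 log units; within the scatter). Compound 4 is therefore estimated at 45 nM, expected between 18 nM and 110 nM.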

Compound 4, antagonist equilibrium constant: 84 nM
For compound 4 the middle estimate is 1.9-fold (0.27 log units) below the measured one; the range from low to high includes it.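

In this assay, the move from 4-fluorophenyl to 3-cyanophenyl on the second core gave a 2.0-fold higher number from compound 3 to compound 4 (0.31 log units; beyond the scatter). Set beside the same change on the first core, this step cannot be told apart from the earlier one: the same change on two cores in this assay, a 1.1-fold higher number (0.04 log units; within the scatter) from compound 1 to compound 2 and a 2.0-fold higher number (0.31 log units; beyond the scatter) from compound 3 to compound 4, 1.8-fold (0.26 log units) apart, within the scatter of two such steps. The two pairs thus show that the change carried across these two cores without a distinguishable difference, but they do not show that it would behave alike on any further core or explain why the steps are this size.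

Going by these compounds, whether an amine or a carboxylic acid in place of the nitrile would also carry across the two cores remains open. So does which part of the difference between the cores accounts for the gap in their values.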